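A few compounds are considered here, and "the series" means these few. Any claim that something is new, unique, unknown or untested is made for them only; others in the source may bear on it.

Values in an assay on CHO-K1 cells for inhibition of 11-beta-hydroxysteroid dehydrogenase type 2 (Mus musculus), read by scintillation proximity assay; a higher number here means a weaker inhibitor, a lower number a stronger inhibitor:
- compound 1, `Cn1c(-c2ccccc2C(F)(F)F)nnc1C12CCC(CNS(C)(=O)=O)(CC1)CC2`: > 4000 nM, a limit of the assay
- compound 2, `CCS(=O)(=O)CCC12CCC(c3nnc(-c4ccccc4Br)n3C)(CC1)CC2`: > 4000 nM, a limit of the assay
- compound 3, `Cn1c(-c2ccccc2C(F)(F)F)nnc1C12CCC(CCCC(C)(F)F)(CC1)CC2`: > 4000 nM, a limit of the assay

Compound 3 thus stands at the limit, and no number is known for it. The same holds for the two other measured compounds (the limit of > 4000 nM in this assay, at which 3 of the 3 values shown sit). For the measured compounds named here, the one step that can be traced, a step that the two limits leave unreadable from compound 1 to compound 3, runs between two limits and its size cannot be read.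

Compound 4 is `CCS(=O)(=O)CCCCC12CCC(c3nnc(-c4ccccc4C(F)(F)F)n3C)(CC1)CC2`. Its difference from compound 3 is (ethylsulfonyl)methyl in place of 1,1-difluoroethyl on a saturated chain carbon, three bonds along the chain from a saturated ring carbon. Going by the values given here, no measured step bears directly on this exchange; the only traced step is unreadable, and compound 2, which also carries an ethylsulfonyl chain, gives in this assay a limit as well. Nothing in the data points to a gain in potency from this change, so compound 4 is expected to remain at or beyond the limit, and the expected step that the limit leaves unreadable from compound 3 to compound 4 is none beyond the scatter. For compound 4 the estimate is 8000 nM, with a range from 2500 nM to 40000 nM.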

Compound 4, half-maximal inhibitory concentration: > 4000 nM
Compound 4 was reported as a limit (the forecaster's own chance of this, stated with the estimate: 85%); the middle value is on the limit's open side.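

Compound 4 gives > 4000 nM in this assay, which is a limit of the assay. Its steps from compound 3 and compound 1 run between two limits, so neither can be read. The compounds shown leave open whether any chain exchange alters inhibition, as all values share one limit: the limit of > 4000 nM in this assay, at which 4 of the 4 values shown sit.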